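Trimming a methyl from the aryl ether of compound 1

This account rests on a few compounds, and the source may have more. Where it says the series, first, only, none or still open, it means among the compounds named here.

Of the compounds shown here, three built on one shared core have been tested in a functional assay on SK-OV-3 cells (Homo sapiens) for antiproliferative activity, read by MTT assay, with a stated time of 24 h; on this read-out lower numbers stand for stronger inhibition and higher numbers for weaker inhibition. Compound 1 `COc1cccc(/C=C/C(=O)c2ccc(OC)c3c2OC(C)(C)C=C3)c1` gives 9360 nM. Compound 2 `COc1ccc(C(=O)/C=C/c2ccc([N+](=O)[O-])cc2)c2c1C=CC(C)(C)O2` gives 3420 nM, and compound 3 `COc1ccc(C(=O)/C=C/c2cccc([N+](=O)[O-])c2)c2c1C=CC(C)(C)O2` gives 9720 nM. Among these three numbers, compound 1 stands second highest: its nearest neighbour is compound 3, with a gap that lies within the scatter, and its furthest is compound 2, reached by a 2.7-fold lower number from compound 1 to compound 2 (0.44 log units; beyond the scatter).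

Compound 4 `COc1ccc(C(=O)/C=C/c2cccc(O)c2)c2c1C=CC(C)(C)O2` differs from compound 1 in one place only: hydrogen in place of methyl on an oxygen on an aromatic ring.

Going by the values given here, only one measured step touches the same group on the same ring, and it gave a 1.0-fold higher number from compound 1 to compound 3 (0.02 log units; within the scatter). The remaining step, a 2.8-fold higher number from compound 2 to compound 3 (0.45 log units; beyond the scatter), moves a nitro group from one ring position to another and does not involve the methoxy group at all. Among the compounds with values here, no measured pair swaps a methyl for a hydrogen on an oxygen, so the change to compound 4 is not directly mirrored anywhere. Within the data shown here, since the one change at this position stayed within the scatter, the expectation for compound 4 is a step of a 1.0-fold lower number from compound 1 to compound 4 (0.02 log units; within the scatter), that is, no shift beyond the scatter in either direction. Compound 4 is therefore estimated at 9000 nM, with a likely range from 4000 nM to 20000 nM.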

Compound 4, half-maximal inhibitory concentration: > 10000 nM
Compound 4: no number, only a limit; the forecaster's own chance of this, stated with the estimate: 5%; middle value at least 1.1-fold (0.04 log units) from the limit.
By their numbers in this assay, from the lowest: compound 2; then compounds 1 and 3 (each within the scatter of the next). At a limit, above all of these: compound 4.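

Where compound 1 carries 3-methoxyphenyl, compound 4 carries 3-hydroxyphenyl, and in this assay compound 4 gives > 10000 nM, which is a limit of the assay and not a number. Removing the methyl gives an at least 1.0-fold higher number from compound 1 to compound 4 (0.02 log units; that floor lies within the scatter), and hydroxy in place of nitro gives an at least 1.0-fold higher number from compound 3 to compound 4 (0.01 log units; that floor lies within the scatter), so at this position a free hydroxy did not bring the number down, yet neither floor shows a loss beyond the scatter. The one step that clears the scatter is an at least 2.9-fold higher number from compound 2 to compound 4 (0.46 log units; beyond the scatter), so 3-hydroxyphenyl does not reach what 4-nitrophenyl gives on this read-out, while the true size of all three steps stays unknown: the limit of > 10000 nM in this assay, at which 1 of the 4 values shown sits.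

Still open, on these data alone, is whether an amine or a longer chain on the oxygen, such as ethoxy, in place of the methoxy would lower the number in this assay. Equally open, as far as these compounds go, is whether a carboxylic acid on that aromatic carbon would give a result closer to that of the hydroxy or of the nitro group.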